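One aryl group for another: compound 2 to compound 4

A few compounds are considered here, and "the series" means these few. Any claim that something is new, unique, unknown or untested is made for them only; others in the source may bear on it.

Compounds measured so far:
Compound 1, `O=C(Nc1cccc(CNc2nccnc2Cl)c1)NC1CCCCC1`, reaches only a limit of the assay in a functional assay on MGC-803 cells (Homo sapiens) for antiproliferative activity, read by MTT assay, with a stated time of 48 h; on this read-out higher numbers stand for weaker inhibition and lower numbers for stronger inhibition; compound 1 stands at > 40000 nM.
Compound 2, `O=C(Nc1cccc(CNc2nccnc2Cl)c1)Nc1ccc(Cl)cc1Br`, gives 7480 nM in this assay.
Compound 3, `O=C(Nc1cccc(CNc2nccnc2Cl)c1)Nc1cccc(C(F)(F)F)c1`, gives 7290 nM in this assay.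

Compound 2 holds the highest of the two numbers that are numbers at all, but compound 3 sits within the scatter of it, so no order between the two can be read. Among the measured compounds shown here, the one step measured into compound 2 is an at least 5.3-fold lower number from compound 1 to compound 2 (0.72 log units; beyond the scatter), where an aromatic ring replaces cyclohexyl on the amide-type nitrogen. Compound 1 sits at the limit of > 40000 nM in this assay, at which 1 of the 3 values shown sits.

Compound 4, `O=C(Nc1cccc(Cl)c1)Nc1cccc(CNc2nccnc2Cl)c1`, differs from compound 2 by 3-chlorophenyl in place of 2-bromo-4-chlorophenyl on an amide-type nitrogen. An aromatic ring remains on that nitrogen, and compound 3, with a different substituent on its ring, gives a number within the scatter of compound 2. Compound 4 is therefore expected to show a 1.1-fold lower number from compound 2 to compound 4 (0.03 log units; within the scatter), no step beyond the scatter. Compound 4 is estimated at 7000 nM, between 3000 nM and 16000 nM.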

Compound 4, half-maximal inhibitory concentration: 5330 nM
Beside the measured number, compound 4's estimate is 1.3-fold (0.12 log units) above it; measured number inside the range.
By their numbers in this assay, from the lowest: compounds 4, 3 and 2 (each within the scatter of the next). At a limit, above all of these: compound 1.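

In this assay, 3-chlorophenyl in place of 2-bromo-4-chlorophenyl on the amide-type nitrogen gives a 1.4-fold lower number from compound 2 to compound 4 (0.15 log units; within the scatter), and chloro in place of trifluoromethyl on an aromatic carbon gives a 1.4-fold lower number from compound 3 to compound 4 (0.14 log units; within the scatter). Both steps lie within the scatter, so a third substituted phenyl group joins the first two without any order among them, and neither dropping the bromo nor exchanging trifluoromethyl for chloro shows a readable effect here. The gain over cyclohexyl now holds for a second aromatic group, with an at least 7.5-fold lower number from compound 1 to compound 4 (0.87 log units; beyond the scatter), a step that starts from a limit of the assay: the limit of > 40000 nM in this assay, at which 1 of the 4 values shown sits.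

What the compounds shown leave open is whether the ring needs any substituent at all, which an unsubstituted phenyl would address. Also open, from the compounds shown here alone, is how a ring carrying a methoxy, an amine or a carboxylic acid would read in this assay.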